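The compounds below may be only part of what the source reports. "The series", "measured", "known", "first", "only" and "open" are said of these compounds alone.

Series notes. Compound 1 `Cc1ccc(Nc2ncc3c(n2)N(C)C(=O)N(c2cc(NC(=O)c4cccc(C(F)(F)F)c4)ccc2C)C3)cc1C` gives 3760 nM in an ADME assay on BaF3 cells (Mus musculus) for antiproliferative activity, read by CellTiter-Glo and CCK-8 assay, with a stated time of 72 h; a higher number here means a weaker inhibitor of growth, a lower number a stronger inhibitor of growth; compound 2 `Cc1ccc(Nc2ncc3c(n2)N(C)C(=O)N(c2cc(NC(=O)c4cccc(C(F)(F)F)c4)ccc2C)C3)cc1` gives 8000 nM. The step of a 2.1-fold higher number from compound 1 to compound 2 (0.33 log units; beyond the scatter) corresponds to hydrogen in place of methyl on an aromatic carbon. Compound 3 `Cc1cc(C)cc(C(=O)Nc2ccc(C)c(N3Cc4cnc(Nc5ccc(C)c(N)c5)nc4N(C)C3=O)c2)c1` returns only a limit in this assay, > 10000 nM, and it stands at the limit of > 10000 nM in this assay, at which 1 of the 3 values shown sits. The difference between the core of compound 3 and the core of compound 1 is not broken down here. Compound 4 `Cc1cccc(C(=O)Nc2ccc(C)c(N3Cc4cnc(Nc5ccc(C)c(N)c5)nc4N(C)C3=O)c2)c1` is not yet measured; it differs from compound 3 by hydrogen in place of methyl on an aromatic carbon. This is the same kind of change as from compound 1 to compound 2, though there the site was ortho to a methyl group and meta to a large group, whereas here it is meta to a large group and meta to a methyl group. Since compound 3 gives only a limit and the earlier step of a 2.1-fold higher number from compound 1 to compound 2 (0.33 log units; beyond the scatter) raised the number, the step that the limit leaves unreadable from compound 3 to compound 4 is expected to be flat or in the same direction. Compound 4 is therefore estimated at 20000 nM in this assay, within 8000 nM to 60000 nM, most likely again reported only as a limit.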

Compound 4, concentration for 50% growth inhibition: > 10000 nM
Compound 4 ended at the assay's limit (the forecaster's own chance of this, stated with the estimate: 80%); the middle value does not contradict the limit.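

Compound 3 and compound 4 both end at a limit in this assay, so no step between them can be read: the limit of > 10000 nM in this assay, at which 2 of the 4 values shown sit.

The compounds shown leave open whether 3,5-dimethylphenyl and 3-methylphenyl differ at all in growth inhibition.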